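A few compounds are considered here, and "the series" means these few. Any claim that something is new, unique, unknown or untested is made for them only; others in the source may bear on it.

In an ADME assay on microsomes from liver (Rattus norvegicus) for metabolic stability, read by LC-MS, using NADPH, with a stated time of 30 min, tested at 0.1 uM, in the presence of a further agent that is not named here (on this read-out lower numbers stand for a less stable compound and higher numbers for a more stable compound), three compounds sharing one core have been measured. Compound 1 `Nc1ncc(-c2ccc(C(=O)N3CC(O)C3)cc2)nc1-c1ccc(C(F)(F)F)cc1`, with 3-hydroxyazetidin-1-yl on its carbonyl carbon, gives > 90%, which is a limit of the assay and not a number. Compound 2 `NC(=O)c1ccc(-c2cnc(N)c(-c3ccc(C(F)(F)F)cc3)n2)cc1`, with amino in that place, gives > 90%, again a limit. Compound 3 `Nc1ncc(-c2ccc(C(=O)N3CCC(O)C3)cc2)nc1-c1ccc(C(F)(F)F)cc1`, with 3-hydroxypyrrolidin-1-yl there, gives > 90%, also a limit. The picture so far is therefore (the limit of > 90% in this assay, at which 3 of the 3 values shown sit), and compound 3 has no exact value of its own.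

Compound 4 `Nc1ncc(-c2ccc(C(=O)N3CC[C@@H](O)C3)cc2)nc1-c1ccc(C(F)(F)F)cc1` is still to be measured. The change is the two compounds have the same atoms and bonds; at least one stereo element is drawn with a configuration in one of them and without one in the other: 1 of 1 stereo elements differ; a stereocentre at a saturated ring carbon is drawn without a configuration in compound 3 and R in compound 4. The two compounds have the same atoms and bonds, and a stereocentre at a saturated ring carbon is drawn without a configuration in compound 3 and R in compound 4.

Going by the values given here, no measured step is a change of this kind. The nearest guides are a step that the two limits leave unreadable from compound 1 to compound 3 and a step that the two limits leave unreadable from compound 2 to compound 3, along with a step that the two limits leave unreadable from compound 1 to compound 2. None of the three has a readable size, yet each of these larger changes on the carbonyl carbon joins two compounds at the same limit. Among the compounds with values here, the expected change is therefore a step that the limit leaves unreadable from compound 3 to compound 4, with no step expected beyond the usual scatter. The estimated value for compound 4 is 93%, expected to fall between 84% and 100%.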

Compound 4, percent of the compound remaining: > 90%
Compound 4: a limit, no number; the forecaster's own chance of this, stated with the estimate: 75%; the middle value lies beyond the limit too.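

Compound 4 reaches the same limit as compounds 1, 2 and 3, so the steps from each of those three to compound 4 cannot be read: the limit of > 90% in this assay, at which 4 of the 4 values shown sit.

The compounds shown leave open how far their stability really differs past that limit, and whether the R configuration drawn in compound 4 makes any difference at all.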